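Bile acid receptor series: aryl replacement in the thioether ring

This account rests on a few compounds, and the source may have more. Where it says the series, first, only, none or still open, it means among the compounds named here.

Measured so far:
compound 1 `Cc1nn(-c2ccccc2I)c2c1C(c1ccc(Oc3ccccc3)cc1)SC(C)C(=O)N2` — 1300 nM
compound 2 `COC(=O)c1ccc(-c2ccc([C@H]3S[C@@H](C)C(=O)Nc4c3c(C)nn4-c3ccccc3C)cc2)cc1` — "not active" (no number reported)
compound 3 `COc1ccc(Oc2ccc([C@H]3S[C@@H](C)C(=O)Nc4c3c(C)nn4-c3ccccc3C)cc2)cc1` — 2200 nM

In an assay on isolated protein for agonist activity at Bile acid receptor (Homo sapiens), read by AlphaScreen, with a stated time of 30 min (a higher number here means that more compound is needed for the effect, a lower number that less compound is needed), compound 3 gives 2200 nM, the higher of the two numbers reported. Its nearest neighbour is compound 1, which in this assay gives 1300 nM, a gap within the scatter of repeated measurements, so no order between compound 1 and compound 3 can be claimed. For the measured compounds named here, compound 2 was reported as not active in this assay; it carries a directly attached aromatic ring in place of the aryl ether, but differs from compound 3 in more than one place, so no single step can be drawn from it.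

Compound 4 `Cc1ccccc1-n1nc(C)c2c1NC(=O)[C@H](C)S[C@@H]2c1ccc(-c2ccco2)cc1` is not yet measured. It differs from compound 3 by furan-2-yl in place of 4-methoxyphenoxy on an aromatic carbon. Going by the values given here, the only comparison available, compound 2 with its directly linked aromatic ring, gives no number in this assay, which leaves the direction of this change uncertain. A step toward a higher number is expected, a 2.3-fold higher number from compound 3 to compound 4 (0.36 log units; beyond the scatter), with a real chance that only a limit is returned. For compound 4 the estimate in this assay is 5000 nM, within 1500 nM to 20000 nM.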

Compound 4, half-maximal effective concentration: 3600 nM
Beside the measured number, compound 4's estimate is 1.4-fold (0.14 log units) above it; low and high end bracket the measured number.
By their numbers in this assay, from the lowest: compounds 1, 3 and 4 (each within the scatter of the next, the first and the last beyond it).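

In this assay, for the compounds shown here, furan-2-yl in place of 4-methoxyphenoxy gives a 1.6-fold higher number from compound 3 to compound 4 (0.21 log units; within the scatter), the first step that changes one place only. On this aromatic carbon, para to a large group, a group of 5 heavy atoms with one five-membered aromatic ring therefore reads the same, within the scatter, as one of 9 heavy atoms with a six-membered aromatic ring of carbon only. No supporting measurement bears on this result, so the step gives no explanation for it.

Still open, as far as these compounds go, is whether a carboxylic acid or a primary amine on the same aromatic carbon would return a number in this assay. Also open, from the compounds shown here alone, is whether any group at this position can move the value beyond the scatter from compound 3, in either direction.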